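The source may report more compounds than this note shows. Statements on the series, on what has been measured and on what is new or still open speak of the compounds shown alone.

Measured in a functional assay on MCF7 cells (Homo sapiens) for antiproliferative activity, read by MTT assay, with a stated time of 72 h; a lower number here means a stronger inhibitor, a higher number a weaker inhibitor:
- compound 1 `COc1ccccc1-c1ccc2ncn(-c3cc(OC)c(OC)c(OC)c3)c2c1`: 1750 nM
- compound 2 `COc1cc(-n2cnc3ccc(-c4cccc(O)c4)cc32)cc(OC)c1OC`: 350 nM
- compound 3 `COc1cc(-n2cnc3ccc(-c4ccc(Cl)cc4Cl)cc32)cc(OC)c1OC`: 5420 nM

Compound 3 has the highest number of the three, and so is the weakest inhibitor in this set. The next analogue, compound 4 `COc1ccc(-c2ccc3ncn(-c4cc(OC)c(OC)c(OC)c4)c3c2)cc1`, differs from it by 4-methoxyphenyl in place of 2,4-dichlorophenyl on an aromatic carbon. Going by the values given here, the nearest precedent is a 3.1-fold higher number from compound 1 to compound 3 (0.49 log units; beyond the scatter), where a 2-methoxyphenyl gives way to the same 2,4-dichlorophenyl. The step of a 15-fold higher number from compound 2 to compound 3 (1.19 log units; beyond the scatter) starts from 3-hydroxyphenyl instead, a group compound 4 lacks, so it weighs less. A modest fall in the number is therefore expected in this assay, and the estimated change is a 3.6-fold lower number from compound 3 to compound 4 (0.56 log units; beyond the scatter). Compound 4 is expected at 1500 nM, with an estimated range of 450 nM to 5000 nM.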

Compound 4, half-maximal inhibitory concentration: 210 nM
Compound 4: the middle estimate sits 7.1-fold (0.85 log units) above what was measured; measured number below the stated range.
By their numbers in this assay, from the lowest: compounds 4 and 2 (each within the scatter of the next); then compound 1; then compound 3.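

In this assay, going by these compounds alone, the step of a 26-fold lower number from compound 3 to compound 4 (1.41 log units; beyond the scatter) shows that this aromatic carbon tolerates a far larger change in the number than the earlier steps suggested. The place of the methoxy group on the phenyl ring also counts, since an 8.3-fold lower number from compound 1 to compound 4 (0.92 log units; beyond the scatter) separates the 4-methoxyphenyl and 2-methoxyphenyl groups. The step of a 1.7-fold lower number from compound 2 to compound 4 (0.22 log units; within the scatter) lies within the scatter, so 4-methoxyphenyl and 3-hydroxyphenyl cannot be ranked. Whether a 4-hydroxyphenyl or 4-aminophenyl group would match them remains open, and no measurement shown explains these differences.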